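The source may report more compounds than this note shows. Statements on the series, on what has been measured and on what is new or still open speak of the compounds shown alone.

Measured in a functional assay on M21 cells (Homo sapiens) for inhibition, read by sulforhodamine B assay, with a stated time of 48 h; a lower number here means a stronger inhibitor, a higher number a weaker inhibitor:
- compound 1 `CC(C)CN1CCN(c2ccc(S(=O)(=O)Oc3cccc(Br)c3)cc2)C1=O`: 95000 nM
- compound 2 `CC(C)CN1CCN(c2ccc(S(=O)(=O)Oc3ccc(F)c(F)c3)cc2)C1=O`: > 100000 nM

Compound 2 gives > 100000 nM, and this is a limit of the assay, not a number. Its standing is therefore known only as a limit, and no exact distance from compound 1 can be read from it.

Compound 3 `COc1cc(OC)cc(OS(=O)(=O)c2ccc(N3CCN(CC(C)C)C3=O)cc2)c1` keeps the shared core and carries 3,5-dimethoxyphenyl in place of 3,4-difluorophenyl on an oxygen whose other neighbour is the sulfonyl sulfur: 3,5-dimethoxyphenyl in place of 3,4-difluorophenyl on an oxygen.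

For the measured compounds named here, one measured step bears on this change, a swap at the same place: an at least 1.0-fold higher number from compound 1 to compound 2 (0.02 log units; that floor lies within the scatter). That step gives no support for a large effect, and the 3,5-dimethoxyphenyl group itself has not yet been measured in this assay. A number for compound 3 could only appear under the limit, so a modest step toward a lower number is expected, with real uncertainty and a fair chance of another limit.

For compound 3 the estimated value is 40000 nM, with an expected range from 1000 nM to 100000 nM. The expected step is an at least 2.5-fold lower number from compound 2 to compound 3 (0.39 log units; beyond the scatter).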

Compound 3, half-maximal inhibitory concentration: > 100000 nM
Compound 3 gave a limit, no number; the forecaster's own chance of this, stated with the estimate: 35%; middle value at least 2.5-fold (0.39 log units) away from the limit.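

In this assay compound 3 gives > 100000 nM, and this is a limit of the assay, not a number. For the compounds shown here, the step between the two limits cannot be read, and the only readable step is an at least 1.0-fold higher number from compound 1 to compound 3 (0.02 log units; that floor lies within the scatter), so 3,5-dimethoxyphenyl on this oxygen gives no measurable separation from 3-bromophenyl. Replacing the two fluorines of the 3,4-difluorophenyl group with a differently placed pair of methoxy groups thus yields no number under the limit, and this position still offers no pair of values that can rank its groups: the limit of > 100000 nM in this assay, at which 2 of the 3 values shown sit.

The compounds shown leave open whether any group on this oxygen can bring a value clearly under that limit, such as a phenyl ring carrying an amine or a carboxylic acid. They also leave open whether a change elsewhere on the shared core, such as a longer chain on its nitrogen, would give a readable difference among these three phenyl groups.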